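Shared urea core: aryl swap on the benzyl group

This account rests on a few compounds, and the source may have more. Where it says the series, first, only, none or still open, it means among the compounds named here.

Measured so far:
- compound 1 `Cc1cc(C)c(NC(=O)N(Cc2ccc(N3CCN(C)CC3)cc2)C2CCCCCC2)c(C)c1`: > 1 mg/kg
- compound 2 `Cc1cc(C)c(NC(=O)N(Cc2ccc(-c3ccsc3)cc2)C2CCCCCC2)c(C)c1`: 0.51 mg/kg

In a functional assay on a cell-free system (plasma) with sterol O-acyltransferase, Soat (Rattus norvegicus) as the target (on this read-out higher numbers stand for an effect only at larger amounts of compound and lower numbers for an effect already at smaller amounts), compound 1 gives only a limit, > 1 mg/kg. In this assay, going by the values given here, compound 2 gives 0.51 mg/kg, the only numerical value in the set so far. The step from one to the other, an at least 1.9-fold lower number from compound 1 to compound 2 (0.29 log units; that floor lies within the scatter), rests on the limit of > 1 mg/kg in this assay, at which 1 of the 2 values shown sits, and so only sets a floor.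

Compound 3 `Cc1cc(C)c(NC(=O)N(Cc2ccc(-c3ccccn3)cc2)C2CCCCCC2)c(C)c1` has not been measured. It differs from compound 2 in one place: pyridin-2-yl in place of thiophen-3-yl on an aromatic carbon. Among the compounds with values here, only the step from compound 1 to compound 2 bears on this, and it exchanged a charged, non-aromatic ring for an aromatic one; here one neutral aromatic ring with a single acceptor is traded for another of the same kind. No movement beyond the scatter is therefore expected. For compound 3 the expected value in this assay is 0.6 mg/kg, between 0.25 mg/kg and 1.5 mg/kg, which is the expected step of a 1.2-fold higher number from compound 2 to compound 3 (0.07 log units; within the scatter).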

Compound 3, dose for half-maximal effect: > 1 mg/kg
Compound 3: only a limit was reported; the forecaster's own chance of this, stated with the estimate: 30%; at least 1.6-fold (0.22 log units) between middle value and limit.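

In this assay compound 3 gives only a limit, > 1 mg/kg. A neutral aromatic ring on this carbon is thus not enough on its own for a numerical value, since pyridin-2-yl in place of thiophen-3-yl, with the same count of hetero atoms and acceptors, gives an at least 1.9-fold higher number from compound 2 to compound 3 (0.29 log units; that floor lies within the scatter), and the size of that step is only a floor: the limit of > 1 mg/kg in this assay, at which 2 of the 3 values shown sit. The step between compound 1 and compound 3 cannot be read, as both values are limits.

On these data alone, the true size of the change from thiophen-3-yl to pyridin-2-yl remains open, so the result does not settle whether the swap matters beyond the scatter. Also open, as far as these compounds go, is how phenyl, thiophen-2-yl or pyridin-3-yl would read on the same aromatic carbon, which would show whether thiophen-3-yl is a special case among aromatic rings here.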